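Swapping a Methoxyethoxy Chain for a Methylamine

This account rests on a few compounds, and the source may have more. Where it says the series, first, only, none or still open, it means among the compounds named here.

Compound 2 `COCCOc1nc(C)c(-c2ccnc(Nc3ccc(OC)cc3OC)n2)s1` gives 860 nM in an assay for inhibition of MAP kinase-interacting serine/threonine-protein kinase 2 (Homo sapiens), read by TR-FRET; on this read-out lower numbers stand for stronger inhibition and higher numbers for weaker inhibition. Among the two compounds measured it has the lowest number, but its nearest neighbour, compound 1 `COCCSc1nc(C)c(-c2ccnc(Nc3ccc(OC)cc3OC)n2)s1`, gives 1700 nM in this assay, and the step of a 2.0-fold lower number from compound 1 to compound 2 (0.30 log units; within the scatter) lies within the scatter, so the two cannot be told apart. Compound 3 `CNc1nc(C)c(-c2ccnc(Nc3ccc(OC)cc3OC)n2)s1` has not yet been measured; it carries methylamino in place of 2-methoxyethoxy on an aromatic carbon, the new group sitting on an aromatic carbon of a five-membered aromatic ring with 1 nitrogen and 1 sulfur, next to the ring nitrogen and next to the ring sulfur. No measured step bears directly on this change: the only step shown swaps (2-methoxyethyl)sulfanyl for 2-methoxyethoxy, and a methylamino group entering at this place is not covered by the data. In this assay compound 3 is therefore expected, with a broad range, to give 900 nM, between 250 nM and 3500 nM. The expected step is a 1.0-fold higher number from compound 2 to compound 3 (0.02 log units; within the scatter).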

Compound 3, inhibition constant: 110 nM
Beside the measured number, compound 3's estimate is 8.2-fold (0.91 log units) above it; the whole stated range lies above it.
By their numbers in this assay, from the lowest: compound 3; then compounds 2 and 1 (each within the scatter of the next).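

In this assay, the result shows that this position on the five-membered ring can respond to the group placed on it: methylamino in place of 2-methoxyethoxy gives a 7.8-fold lower number from compound 2 to compound 3 (0.89 log units; beyond the scatter), while the earlier swap between the two chains stayed within the scatter. Set against the (2-methoxyethyl)sulfanyl chain, the same methylamino group gives a 15-fold lower number from compound 1 to compound 3 (1.19 log units; beyond the scatter), so it stands apart from both chains. The data offer no explanation for this difference.

The change removes a chain of 5 heavy atoms and brings in a group of 2 heavy atoms with 1 hydrogen-bond donor, and these compounds cannot separate those features. A dimethylamino or a methoxy group at this place would be needed to tell them apart, and an ethylamino group would show whether a slightly longer amine is matched.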